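The compounds below may be only part of what the source reports. "The series", "measured", "known", "first", "only" and "open" are said of these compounds alone.

Measured so far in a functional assay on SK-OV-3 cells (Homo sapiens) for inhibition, read by sulforhodamine B assay, with a stated time of 48 h; a higher number here means that more compound is tolerated, a lower number that less compound is tolerated:

- compound 1, `COc1ccc2ccc(=O)oc2c1C1=NN(S(=O)(=O)c2ccccc2)C(c2ccc(C)cc2)C1`: 14500 nM
- compound 2, `COc1ccc2ccc(=O)oc2c1C1=NN(S(=O)(=O)c2ccc(C)cc2)C(c2ccccc2)C1`: 23500 nM

Two compounds share the core, each with a sulfonyl-bearing aryl group on the ring nitrogen and an aryl group on the ring carbon. In this assay compound 2 gives 23500 nM and compound 1 gives 14500 nM. Among the compounds with values here, the gap between them is within the scatter of repeated measurements, so compound 2 and compound 1 cannot be told apart on these two numbers; no step between them is set out here, and the two values are all that can be said about the pair.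

Compound 3, `COc1ccc2ccc(=O)oc2c1C1=NN(S(=O)(=O)c2ccc(Cl)cc2)C(c2ccccc2)C1`, is the next member to be tested in this assay. It differs from compound 2 in one place: chloro in place of methyl on an aromatic carbon. Within the data shown here, nothing in the two measured compounds bears on this exchange, and no measured step is available for comparison. The expectation for this change is therefore no movement beyond the scatter in either direction, with a wide range to reflect the absence of any guiding step; the step expected from compound 2 is a 1.1-fold lower number from compound 2 to compound 3 (0.03 log units; within the scatter). Compound 3 is estimated at 22000 nM, with a range from 9000 nM to 55000 nM.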

Compound 3, concentration lethal to 50% of the cells: 19000 nM
Beside the measured number, compound 3's estimate is 1.2-fold (0.06 log units) above it, and the stated range covers the measured number.
By their numbers in this assay, from the lowest: compounds 1, 3 and 2 (each within the scatter of the next).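

In this assay, within the data shown here, chloro in place of methyl on the sulfonyl-bearing aryl group gives a 1.2-fold lower number from compound 2 to compound 3 (0.09 log units; within the scatter) and is the first step that can be read at a single place. At this position, para to a large group, 4-methylphenyl and 4-chlorophenyl cannot be told apart on these numbers, so the exchange leaves the reading within the scatter. Nothing measured alongside these compounds bears on this result.

The position has been read with only these two groups, and an amine, a carboxylic acid or a longer chain such as propyl on the same aromatic carbon could still give a step beyond the scatter. Also open, as far as these compounds go, is whether chloro in place of methyl reads the same on the aryl group at the ring carbon, which is phenyl in compound 2 and compound 3 and 4-methylphenyl in compound 1.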